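The source may hold more compounds than are shown below. What is called first, only, known or untested is meant among the compounds shown, and "the series" means these compounds.

Measured so far in a functional assay on HT-29 cells (Homo sapiens) for antiproliferative activity, read by MTT assay, with a stated time of 72 h; a higher number here means a weaker inhibitor, a lower number a stronger inhibitor:

Compound 1, `COc1cc2c(Oc3c(F)cc(NC(=O)NN4C(=O)CSC4c4c(F)cccc4F)cc3F)ccnc2cc1OCCCN1CCCC1`, gives 230 nM.
Compound 2, `COc1cc2c(Oc3c(F)cc(NC(=O)NN4C(=O)CSC4c4c(F)cccc4F)cc3F)ccnc2cc1OCCCN1C[C@H]2CCCC[C@H]2C1`, gives 470 nM.

For the measured compounds named here, compound 2 holds the higher of the two numbers, so it is the weaker inhibitor of the pair; its only neighbour is compound 1, and the step of a 2.0-fold higher number from compound 1 to compound 2 (0.31 log units; beyond the scatter) is modest but beyond the scatter.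

Compound 3, `CCN(CC)CCCOc1cc2nccc(Oc3c(F)cc(NC(=O)NN4C(=O)CSC4c4c(F)cccc4F)cc3F)c2cc1OC`, differs from compound 2 in one place: a group of 5 heavy atoms (4 carbon, 1 nitrogen; no ring) in place of a group of 9 heavy atoms (8 carbon, 1 nitrogen; one five-membered non-aromatic ring with 1 hetero atom, one six-membered non-aromatic ring of carbon only), on a saturated chain carbon, three bonds along the chain from an oxygen on an aromatic ring. Going by the values given here, the one measured step that bears on this is a 2.0-fold higher number from compound 1 to compound 2 (0.31 log units; beyond the scatter), where enlarging the amine at this position from a smaller ring to a larger two-ring group raised the number. Compound 3 returns to an amine of the smaller size, though without a ring, so a step back down of about the same size is expected, landing near compound 1.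

Compound 3 is therefore estimated at 250 nM in this assay, within 100 nM to 600 nM, an expected step of a 1.9-fold lower number from compound 2 to compound 3 (0.27 log units; within the scatter).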

Compound 3, half-maximal inhibitory concentration: 91 nM
Beside the measured number, compound 3's estimate is 2.7-fold (0.44 log units) above it; measured number outside the range, below it.
By their numbers in this assay, from the lowest: compound 3; then compound 1; then compound 2.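

In this assay, the open-chain diethylamino group gives a 2.5-fold lower number from compound 1 to compound 3 (0.40 log units; beyond the scatter) in place of pyrrolidin-1-yl, so a ring on this amine is not required for activity, and the group without one gives the lowest number of the three. Both of these groups have the same number of heavy atoms, so group size alone does not set the number at this position; the change from the two-ring group to diethylamino gives the largest step of the series, a 5.2-fold lower number from compound 2 to compound 3 (0.71 log units; beyond the scatter). Nothing measured here explains why the open-chain amine gives the lower number.

The compounds shown leave open whether a smaller open-chain amine such as dimethylamino would lower the number further. They also leave open where a six-membered ring amine such as piperidin-1-yl or morpholin-4-yl would fall.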